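Carbonyl versus methylene on the ring amine: compound 4

The source may report more compounds than this note shows. Statements on the series, on what has been measured and on what is new or still open speak of the compounds shown alone.

Measured so far in an assay on membranes from Cortex for displacement of a labelled ligand from Sigma non-opioid intracellular receptor 1 (Cavia porcellus), read by scintillation counting, with a stated time of 120 min; on this read-out lower numbers stand for stronger inhibition and higher numbers for weaker inhibition:
compound 1 `Fc1ccc(C(SCCNC2CCN(Cc3ccc(C(F)(F)F)cc3)CC2)c2ccc(F)cc2)cc1`: 186 nM
compound 2 `O=C(c1cc2ccccc2[nH]1)N1CCC(NCCSC(c2ccc(F)cc2)c2ccc(F)cc2)CC1`: 1130 nM
compound 3 `Fc1ccc(C(SCCNC2CCN(Cc3cc4ccccc4[nH]3)CC2)c2ccc(F)cc2)cc1`: 205 nM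

Compound 3 stands second highest of the three numbers; its nearest neighbour is compound 1, with a 1.1-fold higher number from compound 1 to compound 3 (0.04 log units; within the scatter), and its furthest is compound 2, with a 5.5-fold lower number from compound 2 to compound 3 (0.74 log units; beyond the scatter).

Compound 4 `O=C(c1ccc(F)cc1F)N1CCC(NCCSC(c2ccc(F)cc2)c2ccc(F)cc2)CC1` is not yet measured. It differs from compound 3 as follows: (2,4-difluorophenyl)carbonyl in place of (1H-indol-2-yl)methyl on an amine nitrogen in a ring.

Going by the values given here, two measured steps bear on this. The step of a 5.5-fold lower number from compound 2 to compound 3 (0.74 log units; beyond the scatter) shows that replacing a carbonyl link on the ring amine by a methylene link gives a clearly lower number; the present change runs the other way, from a methylene link to a carbonyl link. The step of a 6.1-fold higher number from compound 1 to compound 2 (0.78 log units; beyond the scatter) likewise shows a carbonyl-linked group on the ring amine giving a higher number than a methylene-linked one. Among the compounds with values here, no measured pair separates an indol-2-yl from a 2,4-difluorophenyl on the same linker, so that part of the change is uncertain. Overall a modest rise in the number is expected, with compound 4 estimated near the value of compound 2.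

For compound 4 the expected step is a 4.4-fold higher number from compound 3 to compound 4 (0.64 log units; beyond the scatter). Compound 4 is estimated at 900 nM, with a range from 300 nM to 3000 nM.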

Compound 4, inhibition constant: 20.6 nM
Beside the measured number, compound 4's estimate is 44-fold (1.64 log units) above it, outside the stated range (below it).
By their numbers in this assay, from the lowest: compound 4; then compounds 1 and 3 (each within the scatter of the next); then compound 2.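

In this assay a carbonyl link on the ring amine does not by itself raise the number: with 2,4-difluorophenyl in place of 1H-indol-2-yl on the carbonyl carbon there is a 55-fold lower number from compound 2 to compound 4 (1.74 log units; beyond the scatter), a larger step than the link change alone, a 5.5-fold lower number from compound 2 to compound 3 (0.74 log units; beyond the scatter). Compound 4 also goes against the earlier pattern of carbonyl-linked groups giving higher numbers than methylene-linked ones, with a 10-fold lower number from compound 3 to compound 4 (1.00 log units; beyond the scatter) and a 9.0-fold lower number from compound 1 to compound 4 (0.96 log units; beyond the scatter), so that pattern rests on compound 2 alone and the group on the carbonyl carbon counts at least as much as the link. No measurement at hand speaks to the origin of this drop.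

The compounds shown leave open how a (2,4-difluorophenyl)methyl group on the ring amine would compare with compound 4, so for this aryl group the effect of the link remains unseparated from that of the ring. Also open, going by these compounds, is whether the fluorine atoms matter, which a plain phenyl on the carbonyl carbon would test, and whether a sulfonyl link could stand in for the carbonyl.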